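The source may hold more compounds than are shown below. What is called first, only, known or untested is meant among the compounds shown, and "the series" means these compounds.

Measured so far, in a functional assay on NCI-H460 cells (Homo sapiens) for cytotoxicity, read by MTT assay, with a stated time of 2 days; on this read-out lower numbers stand for stronger inhibition and higher numbers for weaker inhibition:
compound 1 `CC(=O)Nc1ccc2c(c1)/C(=N\O)C(c1c[nH]c3ccc(NC(C)=O)cc13)=N2` gives 30200 nM;
compound 2 `Cc1ccc(CO/N=C2/C(c3c[nH]c4ccc(Br)cc34)=Nc3ccc(Br)cc32)cc1` gives 10600 nM;
compound 3 `FC(F)(F)c1ccc(CO/N=C2/C(c3c[nH]c4ccc(Br)cc34)=Nc3ccc(Br)cc32)cc1` gives 11200 nM.

Compound 3 stands second highest of these three numbers. For the measured compounds named here, its nearest neighbour is compound 2, and the step between them, a 1.1-fold higher number from compound 2 to compound 3 (0.02 log units; within the scatter), is the only one-place change measured here; it lies within the scatter, so the swap of methyl for trifluoromethyl on the aromatic carbon did not shift the read-out in any way that can be trusted. Going by the values given here, compound 1 carries a different core decoration and a higher number, and no single step connects it to compound 3, so it says nothing direct about the change at hand.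

Compound 4 `Clc1cccc(CO/N=C2/C(c3c[nH]c4ccc(Br)cc34)=Nc3ccc(Br)cc32)c1` differs from compound 3 in one place: 3-chlorophenyl in place of 4-(trifluoromethyl)phenyl on a saturated chain carbon bound to an oxygen on an unsaturated carbon. Among the compounds with values here, the one measured step that bears on this position, from compound 2 to compound 3, was flat, and a change of substituent on the same distant benzyl ring is expected to behave alike. The step from compound 3 to compound 4 is therefore estimated as a 1.0-fold lower number from compound 3 to compound 4 (0.01 log units; within the scatter), no shift beyond the scatter. On that basis compound 4 is expected to give about 11000 nM in this assay, with a range from 5000 nM to 25000 nM.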

Compound 4, half-maximal inhibitory concentration: 14600 nM
For compound 4 the middle estimate is 1.3-fold (0.12 log units) below the measured one; low and high end bracket the measured number.
By their numbers in this assay, from the lowest: compounds 2, 3 and 4 (each within the scatter of the next); then compound 1.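

In this assay, the third benzyl-type group on this oxime oxygen brings no shift that can be trusted: both new steps (a 1.3-fold higher number from compound 3 to compound 4 (0.12 log units; within the scatter) and a 1.4-fold higher number from compound 2 to compound 4 (0.14 log units; within the scatter)) lie within the scatter. The earlier pair showed only that 4-(trifluoromethyl)phenyl and 4-methylphenyl read alike, with the substituent named at the same ring number, whereas 3-chlorophenyl has a different substituent at a different ring number and still reads alike with both, so across compounds 2, 3 and 4 neither kind of change moves the number beyond the scatter. No measurement offers a reason for this flat result.

On these data alone, what stays open is whether this position responds at all to a group of a different kind, such as an amine or a carboxylic acid on the ring, or a longer chain carrying the ring. For the compounds shown here, also open is how much of the gap to compound 1 comes from this position, since compound 1 differs from the others in more than one place and no single step connects it to them.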